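A few compounds are considered here, and "the series" means these few. Any claim that something is new, unique, unknown or untested is made for them only; others in the source may bear on it.

Measured compounds:
- Compound 1, `COCc1ccccc1C1Cc2nccn2C1`, in a functional assay on CHO cells for agonist activity at Alpha-1D adrenergic receptor (Homo sapiens), read by FLIPR and calcium flux (on this read-out lower numbers stand for an effect already at smaller amounts and higher numbers for an effect only at larger amounts of compound), gives > 10000 nM.
- Compound 2, `c1ccc2c(c1)CC(c1ncc[nH]1)C2`, in this assay gives > 10000 nM.

For compound 1 the value in this assay is only a limit of the assay, not a number, so its true position on the scale is not known. Among the compounds with values here, the same holds for compound 2, whose value in this assay is also a limit. (the limit of > 10000 nM in this assay, at which 2 of the 2 values shown sit), so neither measured compound gives a number to anchor the scale, and no step between measured compounds can be sized.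

Compound 3, `N#Cc1ccccc1C1Cc2nccn2C1`, has not yet been measured in this assay. It differs from compound 1 in one place: cyano in place of methoxymethyl on an aromatic carbon, in words cyano in place of methoxymethyl on an aromatic carbon. The shared core of compound 1 stays unchanged.

Within the data shown here, with no measured step to guide the change, the expected step that the limit leaves unreadable from compound 1 to compound 3 is none beyond the scatter, with no direction given. Compound 3 is therefore expected to sit near 20000 nM, within 5000 nM to 80000 nM, most likely again as a limit.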

Compound 3, half-maximal effective concentration: > 10000 nM
Compound 3: only a limit was reported (the forecaster's own chance of this, stated with the estimate: 75%); the middle value does not contradict the limit.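

Compound 1 and compound 3 both end in a limit of the assay rather than a number, so the step between them cannot be read: the limit of > 10000 nM in this assay, at which 3 of the 3 values shown sit.

From the compounds shown here alone, what stays open is how far apart cyano and methoxymethyl on the aromatic carbon really lie in this assay, and whether either compound gives a measurable effect there.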